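This account rests on a few compounds, and the source may have more. Where it says the series, first, only, none or still open, it means among the compounds named here.

Working notes on the series. In a functional assay on isolated protein for inhibition of Glucose-dependent insulinotropic receptor (Rattus norvegicus), read by HTRF and cAMP accumulation (a lower number here means a smaller maximal response, a higher number a larger maximal response), compound 3 `Cc1nc(S(C)(=O)=O)ccc1Oc1ncnc(OC2CCN(C(=O)O[C@H](C)C(F)(F)F)CC2)c1F` gives 85%, the second highest of the three numbers. Compound 1 `Cc1nc(S(C)(=O)=O)ccc1Oc1ncnc(OC2CCN(C(=O)OC(C)(C)C#N)CC2)c1F` gives 97%, and compound 2 `Cc1nc(S(C)(=O)=O)ccc1Oc1ncnc(OC2CCN(C(=O)OC(C)F)CC2)c1F` gives 68%. Every change made so far sits on the oxygen next to the carbonyl group: a number 12 percentage points lower from compound 1 to compound 3 (beyond the scatter), a number 17 percentage points higher from compound 2 to compound 3 (beyond the scatter) and a number 29 percentage points lower from compound 1 to compound 2 (beyond the scatter), all modest. Compound 4 `Cc1nc(S(C)(=O)=O)ccc1Oc1ncnc(OC2CCN(C(=O)OC3(C(F)(F)F)CCC3)CC2)c1F` continues at the same place: 1-(trifluoromethyl)cyclobutyl in place of 1-(trifluoromethyl)ethyl on an oxygen next to a carbonyl group. The three earlier steps all bear on this position and none exceeded a modest size, so a step of similar or smaller size is expected in this assay, with no clear direction and possibly none beyond the scatter. Compound 4 is therefore estimated at 88% (range 72% to 100%), a step of a number 3 percentage points higher from compound 3 to compound 4 (within the scatter) expected.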

Compound 4, largest response reached (reported as efficacy), in percent of the reference or control that the assay uses: 82%
Compound 4: the middle estimate sits 6 percentage points above what was measured, within the range that was stated.
By their numbers in this assay, from the lowest: compound 2; then compounds 4 and 3 (each within the scatter of the next); then compound 1.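

In this assay, 1-(trifluoromethyl)cyclobutyl in place of 1-(trifluoromethyl)ethyl gives a number 3 percentage points lower from compound 3 to compound 4 (within the scatter), so adding a four-membered carbon ring and losing the defined stereocentre together leave the response in place. Compound 4 stands apart from the other two, with a number 14 percentage points higher from compound 2 to compound 4 (beyond the scatter) and a number 15 percentage points lower from compound 1 to compound 4 (beyond the scatter), and the 1-cyano-1-methylethyl group of compound 1 keeps the largest number. No measurement at hand accounts for these differences.

Open, as far as these compounds go, is whether a cyclobutyl ring carrying a nitrile instead of trifluoromethyl would reach compound 1. Also open, from the compounds shown here alone, is how an amine or a carboxylic acid on this group would read.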